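Trifluoromethyl removal on the urea aryl ring

The source may report more compounds than this note shows. Statements on the series, on what has been measured and on what is new or still open speak of the compounds shown alone.

Compound 3 `COc1cc(Cl)cc(-c2nn(-c3cccc(NC(=O)Nc4cc(C(F)(F)F)cc(C(F)(F)F)c4)c3)cc2-c2ccncc2)c1` stands with the highest number of the three measured compounds. In a functional assay on SK-MEL-5 cells (Homo sapiens) for inhibition, read by sulforhodamine B assay, with a stated time of 48 h, tested at 100 uM (a lower number here means a stronger effect, a higher number a weaker effect of the compound at the concentration tested), compound 3 gives -70%. Compound 2 `O=C(Nc1cccc(-n2cc(-c3ccncc3)c(-c3cc(O)cc(Cl)c3)n2)c1)Nc1ccc(Cl)c(Cl)c1` in this assay gives -78%, and this value and that of compound 3 lie within the scatter of each other. Compound 1 `O=C(Nc1cccc(-n2cc(-c3ccncc3)c(-c3cc(O)cc(Cl)c3)n2)c1)Nc1ccc(Cl)c(C(F)(F)F)c1` in this assay gives -97%, a lower number than that of compound 3 by a gap beyond the scatter.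

Compound 4 `COc1cc(Cl)cc(-c2nn(-c3cccc(NC(=O)Nc4cccc(C(F)(F)F)c4)c3)cc2-c2ccncc2)c1` differs from compound 3 in one place: hydrogen in place of trifluoromethyl on an aromatic carbon. One trifluoromethyl group on the urea aryl ring is thus lost, the other retained.

Going by the values given here, only one measured step touches this part of the series: a number 19 percentage points higher from compound 1 to compound 2 (beyond the scatter), a modest weakening in this assay when a trifluoromethyl on the urea aryl ring was exchanged for chloro. Taking away a trifluoromethyl altogether is a related but not identical change, so a step of similar size and direction, toward a higher number, is the working expectation, with the possibility that it stays within the scatter.

Compound 4 in this assay is therefore estimated at -55%, in the range -75% to -35%, meaning an expected step of a number 15 percentage points higher from compound 3 to compound 4 (beyond the scatter).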

Compound 4, a percentage reported as activity, at one concentration (the size of the read-out at that concentration, not a potency): -99%
The estimate for compound 4 lay 44 percentage points above the measured number; the measured number lies below the stated range.
By their numbers in this assay, from the lowest: compounds 4 and 1 (each within the scatter of the next); then compounds 2 and 3 (each within the scatter of the next).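

In this assay, removing one trifluoromethyl from the urea aryl ring, at a carbon meta to the trifluoromethyl group that remains, gives a number 29 percentage points lower from compound 3 to compound 4 (beyond the scatter), so the lost group is not required for the effect at the concentration tested, and its loss goes with a stronger effect. Going by these compounds alone, the only earlier step at this ring, a number 19 percentage points higher from compound 1 to compound 2 (beyond the scatter), ran the opposite way, so changes to a trifluoromethyl on this ring do not share one direction here, although that step involved chloro rather than hydrogen and a different substitution pattern on the ring, on a core with a hydroxyl where this pair has a methoxy. No measurement at hand offers an explanation for the gain on removal.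

Still open, going by these compounds, is whether hydrogen in place of trifluoromethyl gives a step of the same direction on the hydroxyl-bearing compounds. Also open, on these data alone, is what happens when the remaining trifluoromethyl is itself exchanged for hydrogen, a methoxy, an amine or a carboxylic acid, and whether these single-concentration read-outs would hold as potency differences.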